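Ethylamino in place of acetamido on a second core

This account rests on a few compounds, and the source may have more. Where it says the series, first, only, none or still open, it means among the compounds named here.

The study compares two cores. Compound 1 `CC(=O)Nc1c(C)nc2c(OCc3ccccc3)cccn12` and compound 2 `CC(=O)Nc1c(C)nc2c(CCc3ccccc3)cccn12` carry the same acetamido group; the difference between their two cores is not broken down here. In a functional assay on the whole organism with Rattus norvegicus as the target (a lower number here means that less compound is needed, a higher number that more compound is needed for the effect), compound 1 gives 4.6 mg/kg and compound 2 gives 12 mg/kg, a gap beyond the usual scatter. Compound 3 `CCNc1c(C)nc2c(OCc3ccccc3)cccn12` differs from compound 1 by ethyl in place of acetyl on a nitrogen on an aromatic ring. In this assay compound 3 gives 3.5 mg/kg, so that a 1.3-fold lower number from compound 1 to compound 3 (0.12 log units; within the scatter). Compound 4 `CCNc1c(C)nc2c(CCc3ccccc3)cccn12` is not yet measured; it differs from compound 2 by ethyl in place of acetyl on a nitrogen on an aromatic ring, the same change at the same place as from compound 1 to compound 3. Because a 1.3-fold lower number from compound 1 to compound 3 (0.12 log units; within the scatter) lies within the scatter, the corresponding step in this assay is expected to be of similar size, a 1.3-fold lower number from compound 2 to compound 4 (0.12 log units; within the scatter), an expectation that rests on that single precedent alone. Compound 4 is therefore estimated at 9 mg/kg, with a likely range from 4 mg/kg to 20 mg/kg.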

Compound 4, dose for half-maximal effect: 5.2 mg/kg
For compound 4 the middle estimate is 1.7-fold (0.24 log units) above the measured one; the measured number falls inside the stated range.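

On the core of compound 2, the exchange of acetamido for ethylamino gives a clear step in this assay: a 2.3-fold lower number from compound 2 to compound 4 (0.36 log units; beyond the scatter). Set beside the earlier step on the core of compound 1, the change does not differ measurably between the two cores: the same change on two cores in this assay, a 1.3-fold lower number (0.12 log units; within the scatter) from compound 1 to compound 3 and a 2.3-fold lower number (0.36 log units; beyond the scatter) from compound 2 to compound 4, 1.8-fold (0.24 log units) apart, within the scatter of two such steps. This shows that the step can be carried from one of these cores to the other in this assay with no detectable difference in size, but it rests on two pairs and one assay, one of the two steps lies within the scatter, and it establishes neither a general rule for the series nor any reason for the step.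

The compounds shown leave open how a longer chain such as butyl, or a cyclic amine such as morpholine, would behave on that nitrogen. They also leave open whether the step would keep its size on a third core.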